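A Nitrophenyl Swap Among Weak Antiproliferative Compounds

The source may report more compounds than this note shows. Statements on the series, on what has been measured and on what is new or still open speak of the compounds shown alone.

In a functional assay on MCF7 cells (Homo sapiens) for antiproliferative activity, read by MTT assay, with a stated time of 72 h (on this read-out lower numbers stand for stronger inhibition and higher numbers for weaker inhibition), compound 1 `CC1=CC[C@H]2[C@H](CC[C@]2(C)O)C(C)(C)[C@@H]1CC[C@H]1[C@]2(C)CC[C@H](OC(=O)CCC(=O)O)C(C)(C)O[C@H]2CC[C@@]1(C)O` gives > 50000 nM, which is a limit of the assay and not a number. Compound 2 `CC1=CC[C@H]2[C@H](CC[C@]2(C)O)C(C)(C)[C@@H]1CC[C@H]1[C@]2(C)CC[C@H](OC(=O)c3ccc(C(F)(F)F)cc3)C(C)(C)O[C@H]2CC[C@@]1(C)O` gives 23400 nM. Compound 3 `COc1ccc(C(=O)O[C@H]2CC[C@]3(C)[C@H](CC[C@@](C)(O)[C@H]3CC[C@@H]3C(C)=CC[C@H]4[C@H](CC[C@]4(C)O)C3(C)C)OC2(C)C)cc1` gives 41700 nM, which lies within the scatter of the value for compound 2, so the two stand level.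

Compound 4 `CC1=CC[C@H]2[C@H](CC[C@]2(C)O)C(C)(C)[C@@H]1CC[C@H]1[C@]2(C)CC[C@H](OC(=O)c3ccccc3[N+](=O)[O-])C(C)(C)O[C@H]2CC[C@@]1(C)O` keeps the shared core and carries 2-nitrophenyl in place of 4-methoxyphenyl on a carbonyl carbon. The nearest measured precedent is the exchange between two substituted phenyl groups, a 1.8-fold higher number from compound 2 to compound 3 (0.25 log units; within the scatter). Two further steps start from the 2-carboxyethyl group of compound 1 and bear less directly: an at least 2.1-fold lower number from compound 1 to compound 2 (0.32 log units; beyond the scatter) and an at least 1.1-fold lower number from compound 1 to compound 3 (0.07 log units; that floor lies within the scatter). For the measured compounds named here, no measured compound carries 2-nitrophenyl, so the estimate rests on the swap between compound 2 and compound 3. The expected change in this assay is a 1.4-fold lower number from compound 3 to compound 4 (0.14 log units; within the scatter), and no step beyond the scatter is expected. For compound 4 the estimated value is 30000 nM, with an expected range of 12000 nM to 50000 nM.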

Compound 4, half-maximal inhibitory concentration: 5200 nM
Beside the measured number, compound 4's estimate is 5.8-fold (0.76 log units) above it, outside the stated range (below it).
By their numbers in this assay, from the lowest: compound 4; then compounds 2 and 3 (each within the scatter of the next). At a limit, above all of these: compound 1.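

In this assay, a change of the phenyl group on this carbonyl carbon now gives steps beyond the scatter (an 8.0-fold lower number from compound 3 to compound 4 (0.90 log units; beyond the scatter); a 4.5-fold lower number from compound 2 to compound 4 (0.65 log units; beyond the scatter)), whereas the exchange between the earlier phenyl groups stayed within it (a 1.8-fold higher number from compound 2 to compound 3 (0.25 log units; within the scatter)). Compound 4 is thus the first of these compounds set clearly apart from the others, and its steps to all three are printed as beyond the scatter. Against the 2-carboxyethyl group, the step (an at least 9.6-fold lower number from compound 1 to compound 4 (0.98 log units; beyond the scatter)) gives only a floor and not an exact size, since compound 1 stands at a limit and not at a number: the limit of > 50000 nM in this assay, at which 1 of the 4 values shown sits.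

Still open, going by these compounds, is whether the step belongs to the nitro group itself or to where it sits, as 2-nitrophenyl differs from the groups of compound 2 and compound 3 in both respects. An amine or a nitrile on that ring, or a plain phenyl group, would help to separate the two.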